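The source may report more compounds than this note shows. Statements on the series, on what has been measured and on what is new or still open speak of the compounds shown alone.

Compound 1 `COc1ccc(C2=C(c3cc(OC)c(OC)c(OC)c3)C(=O)CC2C)cc1C(=O)O`: > 100 ug/mL
Compound 2 `COc1ccc(C2=C(c3cc(OC)c(OC)c(OC)c3)C(=O)C(OC(C)=O)C2)cc1`: > 100 ug/mL
Compound 3 `COc1ccc(C2=C(c3cc(OC)c(OC)c(OC)c3)C(=O)CC2O[SiH2]C(C)(C)C)cc1`: > 100 ug/mL

These readings come from an ADME assay on L132 cells (Homo sapiens) for cytotoxicity, read by MTT assay, with a stated time of 72 h; a higher number here means a weaker inhibitor, a lower number a stronger inhibitor. Compound 3 gives > 100 ug/mL, which is a limit of the assay and not a number. It shares this position with the other two compounds, as the data show (the limit of > 100 ug/mL in this assay, at which 3 of the 3 values shown sit). Among the measured compounds shown here, none of the three has a numerical value, and no pair of them differs in only one place, so no single structural change has a measured effect.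

Compound 4 `COc1ccc(OC)c(C2=C(c3cc(OC)c(OC)c(OC)c3)C(=O)CC2O[SiH2]C(C)(C)C)c1` has not yet been measured. Compared with compound 3, it has 2,5-dimethoxyphenyl in place of 4-methoxyphenyl on a double-bonded ring carbon. No step beyond the scatter is expected in this assay, in either direction, because of the limit of > 100 ug/mL in this assay, at which 3 of the 3 values shown sit. This expectation rests on compound 3 and its reading of > 100 ug/mL, which is a limit. The expected step is a number no higher from compound 3 to compound 4 (the limit leaves the size open). For compound 4 the estimated value is 100 ug/mL, with an expected range from 40 ug/mL to 200 ug/mL.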

Compound 4, half-maximal inhibitory concentration: 100 ug/mL
Estimate against measurement, compound 4: no gap at the digits printed; the measured number falls inside the stated range.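

In this assay, compound 4 gives 100 ug/mL, the only actual number among the compounds shown, and it carries 2,5-dimethoxyphenyl where compound 3 carries 4-methoxyphenyl. This single change on a double-bonded ring carbon gives a number no higher from compound 3 to compound 4 (the limit leaves the size open), so the direction is bounded, but the size of the step cannot be read. Compound 3 gives a limit and not a number: the limit of > 100 ug/mL in this assay, at which 3 of the 4 values shown sit.

The compounds shown leave open whether a phenyl ring carrying only one of these two methoxy groups would also give a number in this assay, and so which part of the change matters. They also leave open how this position would read with an amine or a fluorine on that phenyl ring in place of a methoxy group.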